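Trading One Aryl Group for Another on a Shared Core

A few compounds are considered here, and "the series" means these few. Any claim that something is new, unique, unknown or untested is made for them only; others in the source may bear on it.

Three compounds have been measured in a functional assay for antagonist activity at transient receptor potential cation channel subfamily V member 1 (Homo sapiens), read by FLIPR and calcium flux; on this read-out lower numbers stand for stronger inhibition and higher numbers for weaker inhibition:

Compound 1, `COc1cccc(N2CCC(C(=O)Nc3ccc4c(c3)NC(=O)CO4)CC2)c1`, gives 1420 nM.
Compound 2, `Cc1cccc(N2CCC(C(=O)Nc3ccc4c(c3)NC(=O)CO4)CC2)c1C`, gives 60 nM.
Compound 3, `Cc1c(Cl)cccc1N1CCC(C(=O)Nc2ccc3c(c2)NC(=O)CO3)CC1`, gives 100 nM.

Compound 3 holds the second highest of the three numbers. Its nearest neighbour is compound 2, and the step of a 1.7-fold higher number from compound 2 to compound 3 (0.22 log units; within the scatter) lies within the scatter. Its furthest neighbour is compound 1, from which the step of a 14-fold lower number from compound 1 to compound 3 (1.15 log units; beyond the scatter) is large, as is the parallel step a 24-fold lower number from compound 1 to compound 2 (1.37 log units; beyond the scatter).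

Compound 4, `O=C1COc2ccc(NC(=O)C3CCN(c4ccccc4Cl)CC3)cc2N1`, differs from compound 3 in one place: 2-chlorophenyl in place of 3-chloro-2-methylphenyl on an amine nitrogen in a ring. Two of the measured steps bear on it. The step from compound 2 to compound 3 shows that swapping chloro for methyl on an aromatic carbon moved the number little, whereas the steps from compound 1 show that exchanging the whole aryl group can move it a great deal. For the measured compounds named here, no measured step removes a substituent from this aryl group or leaves a single chloro on it, so the evidence is indirect. The change is expected to cost some potency, a step of a 2.5-fold higher number from compound 3 to compound 4 (0.40 log units; beyond the scatter), and compound 4 is therefore estimated at 250 nM, within a range from 80 nM to 800 nM.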

Compound 4, half-maximal inhibitory concentration: 220 nM
For compound 4 the middle estimate is 1.1-fold (0.06 log units) above the measured one; the measured number falls inside the stated range.
By their numbers in this assay, from the lowest: compounds 2 and 3 (each within the scatter of the next); then compound 4; then compound 1.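

In this assay, removing the methyl group from the aryl ring to leave 2-chlorophenyl on the amine nitrogen gives a 2.2-fold higher number from compound 3 to compound 4 (0.34 log units; beyond the scatter), a modest change showing that the second substituent is worth something at this position but is not essential for a number far lower than that of compound 1. The step of a 3.7-fold higher number from compound 2 to compound 4 (0.56 log units; beyond the scatter) is also modest and points the same way, while a 6.5-fold lower number from compound 1 to compound 4 (0.81 log units; beyond the scatter) shows that 2-chlorophenyl keeps much of the gain over 3-methoxyphenyl, although each of these two aryl groups carries a single substituent. No measurement explains why these numbers differ.

The compounds shown leave open whether the remaining gain belongs to the chloro group or is lost through the methoxy group. They also leave open what an unsubstituted phenyl group, or a fluoro or nitrile substituent on the aryl ring, would give.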